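Hydroxy-methoxyphenyl replaces methoxyphenyl: compound 2 to compound 4

The compounds below may be only part of what the source reports. "The series", "measured", "known", "first", "only" and "open" are said of these compounds alone.

compound 1 `COc1cccc(C2SCC(=O)N2c2nnc(CNn3c(C)nc4ccccc4c3=O)s2)c1`: 60%
compound 2 `COc1ccc(/C=N/c2nnc(CNn3c(C)nc4ccccc4c3=O)s2)cc1`: 50%
compound 3 `Cc1nc2ccccc2c(=O)n1NCc1nnc(N2C(=O)CSC2c2ccc(O)cc2)s1`: 60%

In a functional assay on the whole organism (strain albino) with Rattus norvegicus as the target, in the maximal electroshock model, with a stated time of 1 h, at a dose of 30 mg/kg by the intraperitoneal route (on this read-out lower numbers stand for less inhibition and higher numbers for more inhibition at the one dose given (going by the name of the read-out)), compound 2 shows the lowest of the three numbers, yet its gaps to compound 1 and compound 3 both lie within the scatter, so the three stand level. Compound 4 `COc1cc(/C=N/c2nnc(CNn3c(C)nc4ccccc4c3=O)s2)ccc1O` differs from compound 2 by 4-hydroxy-3-methoxyphenyl in place of 4-methoxyphenyl on a carbon with a double bond to nitrogen. For the measured compounds named here, only one measured step exists, no change at the digits printed from compound 1 to compound 3 (within the scatter), and it swapped an aryl group on a saturated ring carbon rather than on a carbon with a double bond to nitrogen, giving no change. Going by the values given here, no measured step touches the place altered here. With that single, flat precedent, the expected step from compound 2 is none beyond the scatter, no change at the digits printed from compound 2 to compound 4 (within the scatter). Compound 4 is therefore estimated at 50%, in the range 30% to 70%.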

Compound 4, a percentage reported as inhibition, in the whole organism at one dose (the size of the read-out at that dose, not a potency): 50%
Compound 4: middle estimate and measured number agree at the digits printed; the measured number falls inside the stated range.
By their numbers in this assay, from the lowest: compounds 2, 4, 1 and 3 (each within the scatter of the next).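

For the compounds shown here, this is the first measured change at the aryl group on a carbon with a double bond to nitrogen: in this assay, 4-hydroxy-3-methoxyphenyl in place of 4-methoxyphenyl gives no change at the digits printed from compound 2 to compound 4 (within the scatter). The entering group carries a hydrogen-bond donor that the leaving group lacks, yet the read-out stays level at this single dose. No available measurement bears on why the number holds.

The compounds shown leave open whether an amine or a carboxylic acid on this phenyl ring would move the number. A single dose also cannot show whether potency differs among these compounds.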